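This account rests on a few compounds, and the source may have more. Where it says the series, first, only, none or still open, it means among the compounds named here.

The study concerns a set of compounds built on one shared core, tested for antiproliferative activity. Compound 1 `COc1ccccc1-n1nncc1CN1C(=O)C2(C(C#N)=C(N)Oc3c2c2nc4ccccc4nc2c2ccccc32)c2ccccc21` carries a 2-methoxyphenyl group on an aromatic nitrogen. In a functional assay on HepG2 cells (Homo sapiens) for antiproliferative activity, read by MTT assay, with a stated time of 48 h (on this read-out higher numbers stand for weaker inhibition and lower numbers for stronger inhibition), compound 1 reaches only the limit of the assay, > 50000 nM. Compound 2 `N#CC1=C(N)Oc2c(c3nc4ccccc4nc3c3ccccc23)C12C(=O)N(Cc1cnnn1-c1ccc(N)cc1)c1ccccc12` carries 4-aminophenyl in place of 2-methoxyphenyl on an aromatic nitrogen. In this assay compound 2 likewise stops at a limit, > 50000 nM. The step that the two limits leave unreadable from compound 1 to compound 2 therefore cannot be read. Compound 3 `COc1ccccc1-n1nncc1CN1C(=O)C2(C(C#N)=C(N)Oc3c(N)cc4nc5ccccc5nc4c32)c2ccccc21` is the third measured compound. In this assay compound 3 also gives only a limit, > 50000 nM. Compound 3 thus stands at the limit of > 50000 nM in this assay, at which 3 of the 3 values shown sit, with no number to place it among the others. Compound 4 `COc1ccc(OC)c(-n2nncc2CN2C(=O)C3(C(C#N)=C(N)Oc4c(N)cc5nc6ccccc6nc5c43)c3ccccc32)c1` has not yet been measured. It differs from compound 3 by methoxy in place of hydrogen on an aromatic carbon. Among the measured compounds shown here, no measured step bears directly on this change: the one step known, from one aryl group to another on the aromatic nitrogen, is itself unreadable, and every value shown sits at the same limit. The expectation is therefore of no movement beyond the scatter, an estimated step that the limit leaves unreadable from compound 3 to compound 4. Compound 4 is expected to give 60000 nM, within 30000 nM to 200000 nM, most probably again only as a limit.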

Compound 4, half-maximal inhibitory concentration: 45100 nM
Estimate against measurement, compound 4: 1.3-fold (0.12 log units) above; the measured number falls inside the stated range.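

Methoxy in place of hydrogen on this aromatic carbon, para to a methoxy group, gives the first step in this assay that can be read at all: an at least 1.1-fold lower number from compound 3 to compound 4 (0.04 log units; that floor lies within the scatter). Only a floor can be stated for that step, and as it lies within the scatter, 2,5-dimethoxyphenyl cannot be said to differ from 2-methoxyphenyl on this evidence. What the result adds is that compound 4 yields a measured number and not a limit, while the other compounds all remain at one limit: the limit of > 50000 nM in this assay, at which 3 of the 4 values shown sit.

The compounds shown leave open whether a hydroxyl group, an amine or an ethoxy group on this carbon would move the number beyond the scatter. Also open, going by these compounds, is whether 2,5-dimethoxyphenyl on the core of compound 1 would give a number.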